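The source may report more compounds than this note shows. Statements on the series, on what has been measured and on what is new or still open speak of the compounds shown alone.

Working notes on the oxamide series

The shared core carries an aspartyl acid and a tetrafluorophenoxymethyl ketone; the three measured compounds differ in the aryl group on the amide-type nitrogen of the oxamide and, for compound 3, in the ester linkage of the ketone. In a functional assay on THP-1 cells (Homo sapiens) for inhibition (a higher number here means a weaker inhibitor, a lower number a stronger inhibitor), compound 1 `C[C@H](NC(=O)C(=O)Nc1ccccn1)C(=O)N[C@@H](CC(=O)O)C(=O)COc1c(F)c(F)cc(F)c1F` gives 200 nM, the lowest number of the three. Compound 3 `C[C@H](NC(=O)C(=O)Nc1ccccc1-c1ccccc1)C(=O)N[C@@H](CC(=O)O)C(=O)COC(=O)c1c(F)c(F)cc(F)c1F` gives 500 nM in this assay, and compound 2 `C[C@H](NC(=O)C(=O)Nc1cc(C(C)(C)C)ccc1C(C)(C)C)C(=O)N[C@@H](CC(=O)O)C(=O)COc1c(F)c(F)cc(F)c1F` gives 1840 nM; both gaps to compound 1 lie beyond the scatter, so compound 1 is the strongest inhibitor measured here.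

Compound 4 `C[C@H](NC(=O)C(=O)Nc1cccc2ccccc12)C(=O)N[C@@H](CC(=O)O)C(=O)COc1c(F)c(F)cc(F)c1F` is not yet measured. It differs from compound 1 in one place: naphthalen-1-yl in place of pyridin-2-yl on an amide-type nitrogen. The two measured compounds with larger carbon-only aryl groups, compound 2 and compound 3, both give higher numbers than compound 1, though neither matches the change to compound 4 exactly and compound 3 also differs in the ketone linkage. On that basis a weakening is expected, modest in size, with the step from a 2.8-fold higher number from compound 1 to compound 4 (0.44 log units; beyond the scatter) estimated to lie beyond the scatter but short of the gap to compound 2. For compound 4 the estimate in this assay is 550 nM, with a range of 180 nM to 1700 nM.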

Compound 4, half-maximal inhibitory concentration: 60 nM
The estimate for compound 4 lay 9.2-fold (0.96 log units) above the measured number, and the stated range ends above it.
By their numbers in this assay, from the lowest: compound 4; then compound 1; then compound 3; then compound 2.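

At the amide-type nitrogen, naphthalen-1-yl in place of pyridin-2-yl gives a 3.3-fold lower number from compound 1 to compound 4 (0.52 log units; beyond the scatter) in this assay, so compound 4 now has the lowest number in the series and this position tolerates a carbon-only aryl group with two rings. Compound 2 also carries a carbon-only aryl group at this nitrogen and differs from compound 1 only there, yet compound 2 gives 1840 nM, so carbon-only aryl groups here do not shift the number in a single direction, and compound 2 goes against any such pattern. No supporting measurement bears on the reason for the step.

The compounds shown leave open whether the step follows from the added ring or from the loss of the ring nitrogen, and a plain phenyl group on this nitrogen would separate the two. Also open, from the compounds shown here alone, is whether the low number of compound 4 survives a methoxy group or an amine on the naphthalen-1-yl group, or a change in the ketone linkage of the shared core.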